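A nitro analogue in the cytotoxicity screen

The source may report more compounds than this note shows. Statements on the series, on what has been measured and on what is new or still open speak of the compounds shown alone.

Compound 1, `COc1ccccc1-c1nnc(-c2sc(-c3cccnc3)nc2C)o1` — in an ADME assay on HeLa cells (Homo sapiens) for cytotoxicity, read by MTT assay (on this read-out higher numbers stand for lower toxicity in this test and lower numbers for higher toxicity in this test), compound 1 reaches the limit > 100 ug/mL.
Compound 2, `Cc1nc(-c2cccnc2)sc1-c1nnc(-c2cccc(Cl)c2Cl)o1` — in this assay compound 2 reaches the limit > 100 ug/mL.
Compound 3, `Cc1cccc(-c2nnc(-c3sc(-c4cccnc4)nc3C)o2)c1` — in this assay compound 3 reaches the limit > 100 ug/mL.

Compound 1 stands only at a limit in this assay; the same holds for the other two compounds, as all three values sit at the limit of > 100 ug/mL in this assay, at which 3 of the 3 values shown sit. Compound 4, `Cc1nc(-c2cccnc2)sc1-c1nnc(-c2ccccc2[N+](=O)[O-])o1`, has not yet been measured in this assay. It differs from compound 1 by nitro in place of methoxy on an aromatic carbon. The two steps that start from compound 1, a step that the two limits leave unreadable from compound 1 to compound 2 and a step that the two limits leave unreadable from compound 1 to compound 3, say nothing about size, and the step that the two limits leave unreadable from compound 2 to compound 3 is equally unreadable. So the measured steps give no scale for the change to the nitro group. Among the measured compounds shown here, since every compound measured so far sits at the limit, compound 4 is expected to do the same, with an estimated step that the limit leaves unreadable from compound 1 to compound 4 that is not expected to go beyond the scatter. For compound 4 the estimate is 150 ug/mL, with a range from 50 ug/mL to 500 ug/mL.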

Compound 4, half-maximal cytotoxic concentration: > 100 ug/mL
Compound 4 ended at the assay's limit (the forecaster's own chance of this, stated with the estimate: 80%); the middle value lies beyond the limit too.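

Compound 1 and compound 4 both stand only at a limit, so no size can be read for the step between them: the limit of > 100 ug/mL in this assay, at which 4 of the 4 values shown sit.

The compounds shown leave open how far any of them lies beyond that limit in this assay, and whether nitro in place of methoxy changes the read-out at all.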